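Aryl change on the ring nitrogen: estimating compound 4

The source may report more compounds than this note shows. Statements on the series, on what has been measured and on what is new or still open speak of the compounds shown alone.

Measured compounds:
- Compound 1 `CC1(C)[C@H]2CC[C@]1(C)N(Cc1cn(-c3ccc(C#N)cc3)nn1)C(=O)C2` gives 140 nM in a functional assay on A549 cells (Homo sapiens) for inhibition, read by MTT assay, with a stated time of 24 h; on this read-out higher numbers stand for weaker inhibition and lower numbers for stronger inhibition.
- Compound 2 `CC1(C)[C@H]2CC[C@]1(C)N(Cc1cn(-c3ccccc3F)nn1)C(=O)C2` gives 240 nM in this assay.
- Compound 3 `CC1(C)[C@H]2CC[C@]1(C)N(Cc1cn(-c3ccc(Br)cc3)nn1)C(=O)C2` gives 80 nM in this assay.

Compound 2 carries the highest number of the three in this assay. Its nearest neighbour is compound 1, a 1.7-fold higher number from compound 1 to compound 2 (0.23 log units; within the scatter), a gap within the scatter; the gap to compound 3, a 3.0-fold lower number from compound 2 to compound 3 (0.48 log units; beyond the scatter), lies beyond it. The unmeasured compound 4 `CC1(C)[C@H]2CC[C@]1(C)N(Cc1cn(-c3ccc(Cl)cc3)nn1)C(=O)C2` differs from compound 2 only at the aryl group on the ring nitrogen: 4-chlorophenyl in place of 2-fluorophenyl on an aromatic nitrogen.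

The measured step that bears most directly on this change is a 3.0-fold lower number from compound 2 to compound 3 (0.48 log units; beyond the scatter), the same kind of exchange with a different halogen entering. The step of a 1.8-fold lower number from compound 1 to compound 3 (0.24 log units; within the scatter) is also relevant, since bromo in place of cyano on an aromatic carbon stays within the scatter. Compound 3 is therefore the anchor for compound 4, and a modest move toward its value is expected. Going by the values given here, no measured step compares 4-bromophenyl with 4-chlorophenyl, so the range is kept wide. The expected step in this assay is a 2.4-fold lower number from compound 2 to compound 4 (0.38 log units; beyond the scatter). Compound 4 is estimated at 100 nM, with a range of 50 nM to 200 nM.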

Compound 4, half-maximal inhibitory concentration: 70 nM
Beside the measured number, compound 4's estimate is 1.4-fold (0.15 log units) above it; measured number inside the range.
By their numbers in this assay, from the lowest: compounds 4, 3, 1 and 2 (each within the scatter of the next, the first and the last beyond it).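

The step of a 3.4-fold lower number from compound 2 to compound 4 (0.54 log units; beyond the scatter) in this assay gives a second 4-halophenyl group that lies beyond the scatter of the 2-fluorophenyl group of compound 2, so the earlier gap is not confined to the bromo compound. However, this exchange alters both the halogen and its place on the phenyl ring, and the single step does not separate the two changes. Chloro and bromo on the aromatic carbon are not told apart, with a 1.1-fold lower number from compound 3 to compound 4 (0.06 log units; within the scatter) inside the scatter, and the 4-cyanophenyl group of compound 1 also stays within the scatter of compound 4, with a 2.0-fold lower number from compound 1 to compound 4 (0.30 log units; within the scatter) as the printed step, so at this position only the 2-fluorophenyl compound separates from the two 4-halophenyl compounds, while compound 1 separates from none of the others.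

The compounds shown leave open how a 4-fluorophenyl or 2-chlorophenyl group would read here, and whether an amine, a carboxylic acid or a methoxy group on the phenyl ring would keep the numbers of the 4-halophenyl compounds. Nothing at hand accounts for the gap between the 2-fluorophenyl and 4-chlorophenyl groups.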